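The source may hold more compounds than are shown below. What is called first, only, known or untested is meant among the compounds shown, and "the series" means these compounds.

Measured so far:
- compound 1, `COc1ccc(CCCc2ccc(OC)c(OC)c2)c(O)c1`: 91.7%
- compound 2, `COc1ccc(C(=O)/C=C/c2ccc(OC)c(OC)c2OC)c(O)c1`: 96.6%

In an ADME assay on RAW264.7 cells (Mus musculus) for cytotoxicity, read by MTT assay, with a stated time of 24 h, tested at 2.5 ug/mL (a higher number here means a weaker effect of the compound at the concentration tested, a lower number a stronger effect), compound 1 gives 91.7%. Of the two numbers, this is the smaller one, but compound 2, with 96.6%, sits within the usual scatter of it, so the two compounds do not differ on this measure; both leave most of the cells alive at the concentration tested. Compound 3, `COc1ccc(CCCc2ccc(OC)c(OC)c2OC)c(O)c1`, has not yet been measured. It differs from compound 1 in one place: methoxy in place of hydrogen on an aromatic carbon. Among the compounds with values here, no pair of measured compounds that differ in a single place is available, so the size of this kind of step cannot be read from the data. Since both measured compounds give high numbers that lie together, the expected step is a number 0.3 percentage points higher from compound 1 to compound 3 (within the scatter), no larger than the scatter. Compound 3 is therefore estimated to give 92%, within a range from 82% to 100%.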

Compound 3, a percentage reported as activity, at one concentration (the size of the read-out at that concentration, not a potency): 95.5%
Estimate against measurement, compound 3: 3.5 percentage points below; measured number inside the range.
By their numbers in this assay, from the lowest: compounds 1, 3 and 2 (each within the scatter of the next).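

Within the data shown here, the step from hydrogen to methoxy is the first single-place change that can be read here: in this assay, placing methoxy on this aromatic carbon, ortho to a large group, ortho to one methoxy group and meta to another, gives a number 3.8 percentage points higher from compound 1 to compound 3 (within the scatter) and so does not separate the two compounds. At this position, then, a methoxy group is compatible with a high number, and the cells fare alike with or without it at the concentration tested. Nothing in the data accounts for this outcome.

The compounds shown leave open whether an amine, a carboxylic acid or a longer chain on this same carbon would also give a high number. They also leave open whether compound 1 and compound 3 would remain indistinguishable at a higher concentration.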